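A few compounds are considered here, and "the series" means these few. Any claim that something is new, unique, unknown or untested is made for them only; others in the source may bear on it.

Measured in a functional assay on KB cells (Homo sapiens) for antiproliferative activity, with a stated time of 72 h; on this read-out lower numbers stand for stronger inhibition and higher numbers for weaker inhibition:
- Compound 1 `C=C1C=CC(=O)[C@@H]2[C@H](Cc3ccc(OCOC)c(F)c3)CC[C@H]12`: 76.6 nM
- Compound 2 `C=C1C=CC(=O)[C@@H]2[C@H](Cc3ccc(OC)c(F)c3)CC[C@H]12`: 2.77 nM
- Compound 3 `C=C1C=CC(=O)[C@@H]2[C@H](Cc3ccc(O)cc3)CC[C@H]12`: 68.8 nM

On these numbers, compound 3 lies within the scatter of compound 1 and well above compound 2. Compound 4 `C=C1C=CC(=O)[C@@H]2[C@H](Cc3ccc(O)c(F)c3)CC[C@H]12` differs from compound 3 by one change: fluoro in place of hydrogen on an aromatic carbon. Among the measured compounds shown here, no measured step isolates this fluoro in place of hydrogen. For the measured compounds named here, the only step available, a 28-fold lower number from compound 1 to compound 2 (1.44 log units; beyond the scatter), is large, but it lies elsewhere and both of its compounds carry the fluoro, so it bears only indirectly. It shows that fluoro compounds can differ widely in this assay, so a moderate fall, with wide uncertainty, is expected. The expected step is a 3.4-fold lower number from compound 3 to compound 4 (0.54 log units; beyond the scatter). Compound 4 is estimated at 20 nM, within an expected range of 5 nM to 70 nM.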

Compound 4, half-maximal inhibitory concentration: 156 nM
Compound 4: the middle estimate sits 7.8-fold (0.89 log units) below what was measured; measured number outside the range, above it.
By their numbers in this assay, from the lowest: compound 2; then compounds 3 and 1 (each within the scatter of the next); then compound 4.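

In this assay, fluoro in place of hydrogen ortho to a hydroxy group brings no gain on this free phenol; the number rises modestly (a 2.3-fold higher number from compound 3 to compound 4 (0.36 log units; beyond the scatter)). With the fluoro present, the group on the oxygen matters far more: hydrogen in place of methyl costs much (a 56-fold higher number from compound 2 to compound 4 (1.75 log units; beyond the scatter)), while hydrogen in place of methoxymethyl costs little (a 2.0-fold higher number from compound 1 to compound 4 (0.31 log units; beyond the scatter)). Nothing available explains these steps. From the compounds shown here alone, whether a chloro or an amine on that aromatic carbon would behave like fluoro remains open. So does whether an ethyl group on the oxygen would hold the low number of compound 2 2.77 nM.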